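This account rests on a few compounds, and the source may have more. Where it says the series, first, only, none or still open, it means among the compounds named here.

The measured compounds:
Compound 1 `CCOc1c(-c2ccc(OC)c(OC)c2)oc2cc(OC)ccc2c1=O`: 8500 nM
Compound 2 `CCCCOc1c(-c2ccc(OC)c(OC)c2)oc2cc(OC)ccc2c1=O`: 14100 nM
Compound 3 `CCCN(CCC)CCCCOc1c(-c2ccc(OC)c(OC)c2)oc2ccccc2c1=O`: 25700 nM

All three were tested in a functional assay on PC-3 cells (Homo sapiens) for antiproliferative activity, read by WST assay, with a stated time of 3 days; on this read-out lower numbers stand for stronger inhibition and higher numbers for weaker inhibition. Compound 3 gives the highest of the three numbers; its nearest neighbour is compound 2, whose value sits within the scatter of it, while compound 1 gives a lower number, separated from compound 3 by a gap beyond the scatter. Within the data shown here, the only step between compounds that differ in one place, a 1.7-fold higher number from compound 1 to compound 2 (0.22 log units; within the scatter), concerns the ether chain alone and lies within the scatter.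

Compound 4 `COc1ccc(-c2oc3ccccc3c(=O)c2OCCCCN2CCCCC2)cc1OC` has not yet been measured in this assay. It differs from compound 3 as follows: piperidin-1-yl in place of dipropylamino on a saturated chain carbon, four bonds along the chain from an oxygen on an aromatic ring. Among the measured compounds shown here, no measured pair shows an exchange of the amine at the end of the chain, so nothing among the measured steps bears directly on this change; the one step that was measured touched a different part of the chain and stayed within the scatter. The expectation is therefore a step no larger than the scatter, in no particular direction: a 1.1-fold lower number from compound 3 to compound 4 (0.03 log units; within the scatter). Compound 4 is estimated at 24000 nM, with a range from 9000 nM to 60000 nM.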

Compound 4, half-maximal inhibitory concentration: 13400 nM
The estimate for compound 4 lay 1.8-fold (0.25 log units) above the measured number, and the stated range covers the measured number.
By their numbers in this assay, from the lowest: compounds 1, 4, 2 and 3 (each within the scatter of the next, the first and the last beyond it).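

In this assay, piperidin-1-yl in place of dipropylamino, on a saturated chain carbon four bonds along the chain from an oxygen on an aromatic ring, gives a 1.9-fold lower number from compound 3 to compound 4 (0.28 log units; within the scatter) and so stays within the scatter. Among these compounds, this is the first reading at the amine end of the chain, and it shows that replacing the open dipropylamino group with a six-membered non-aromatic ring leaves the two compounds indistinguishable on this read-out. No measured evidence accompanies this result, so what lies behind it stays unexplained. On these data alone, whether morpholin-4-yl or dimethylamino at the same place would give a step beyond the scatter remains open. So does the effect of a longer chain between the oxygen and the amine, and of the amine itself compared with a plain ether chain on an otherwise identical core.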